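Hydroxymethyl in Place of Fluoro at the Pendant Ring

The source may report more compounds than this note shows. Statements on the series, on what has been measured and on what is new or still open speak of the compounds shown alone.

Three compounds share one core and differ only in the aryl group attached to it. Compound 1 `Fc1ccc(C2(c3ccc(F)cc3)CNC(c3ccc(C(F)(F)F)cc3)=N2)cc1` carries a trifluoromethyl-substituted ring and gives 160 nM in an assay on LM cells for displacement of a labelled ligand from Neuropeptide Y receptor type 5 (Homo sapiens); a higher number here means a weaker inhibitor, a lower number a stronger inhibitor. Compound 2 `Fc1ccc(C2(c3ccc(F)cc3)CNC(c3cccc(Br)c3)=N2)cc1` carries a bromo-substituted ring and gives 4.8 nM in this assay. Compound 3 `Fc1ccc(C2(c3ccc(F)cc3)CNC(c3cccc(F)c3)=N2)cc1` carries a fluoro-substituted ring and gives 10 nM in this assay. Among these three numbers compound 3 stands second highest: the single measured step, a 2.1-fold higher number from compound 2 to compound 3 (0.32 log units; beyond the scatter), separates it from compound 2, whereas compound 1 lies far above it with a much higher number. Compound 4 `OCc1cccc(C2=NC(c3ccc(F)cc3)(c3ccc(F)cc3)CN2)c1` is the next member of the series; its change from compound 3 is hydroxymethyl in place of fluoro on an aromatic carbon. Going by the values given here, no measured step bears directly on this exchange: the only step at hand, a 2.1-fold higher number from compound 2 to compound 3 (0.32 log units; beyond the scatter), swaps one halogen for another and was modest. A larger movement in this assay than that step, in either direction, is therefore not ruled out, but the expectation for compound 4 is a modest rise in the number, as a step of a 2.5-fold higher number from compound 3 to compound 4 (0.40 log units; beyond the scatter). Compound 4 is therefore estimated at 25 nM in this assay, within a range from 6 nM to 100 nM.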

Compound 4, half-maximal inhibitory concentration: 59 nM
Compound 4: the middle estimate sits 2.4-fold (0.37 log units) below what was measured, and the stated range covers the measured number.
By their numbers in this assay, from the lowest: compound 2; then compound 3; then compound 4; then compound 1.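

In this assay, hydroxymethyl in place of fluoro gives a 5.9-fold higher number from compound 3 to compound 4 (0.77 log units; beyond the scatter), a larger movement at this place on the aromatic ring than the exchange of one halogen for another, a 2.1-fold higher number from compound 2 to compound 3 (0.32 log units; beyond the scatter). Set against bromo, the same group gives a 12-fold higher number from compound 2 to compound 4 (1.09 log units; beyond the scatter), the only step at this place graded as large, so both halogens give lower numbers here than a group carrying a hydrogen-bond donor and acceptor, at least in this small set. Nothing available explains this rise.

The compounds shown do not separate the contribution of the added carbon from that of the oxygen, a question that a plain methyl or a methoxy group at this place could address. On these data alone, how an aminomethyl group or a carboxylic acid would behave here also remains open.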